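Amide Aryl Exchange in the Sulfonylurea Series

A few compounds are considered here, and "the series" means these few. Any claim that something is new, unique, unknown or untested is made for them only; others in the source may bear on it.

Compound 2 `O=C(NC[C@@H]1C[C@@H]2C=C[C@@H]1C2)NS(=O)(=O)N1CCC(CCNC(=O)c2cc(Cl)cc3cccnc23)CC1` stands highest of the two numbers in hand in a functional assay on the whole organism (blood) with Rattus norvegicus as the target, with stated times of 24 h and 1 h, at a dose of 5 mg/kg by the intraperitoneal route (on this read-out higher numbers stand for a stronger effect at the one dose given and lower numbers for a weaker effect), where compound 2 gives 35%. Compound 1 `CC(=O)NCCC1CCN(S(=O)(=O)NC(=O)NC[C@@H]2C[C@@H]3C=C[C@@H]2C3)CC1` is its nearest neighbour and lower: in this assay compound 1 gives 18%. Going by the values given here, the single measured step, a number 17 percentage points higher from compound 1 to compound 2 (beyond the scatter), is the only guide to how the group on the carbonyl carbon moves this read-out.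

Compound 3 `O=C(NC[C@@H]1C[C@@H]2C=C[C@@H]1C2)NS(=O)(=O)N1CCC(CCNC(=O)c2cccc3c2OCCO3)CC1` is not yet measured. 2,3-dihydro-1,4-benzodioxin-5-yl in place of 6-chloroquinolin-8-yl on a carbonyl carbon

Among the compounds with values here, that earlier step bears only indirectly: it replaced a methyl with a bicyclic aromatic group and raised the number beyond the scatter, whereas here one bicyclic group is exchanged for another; the entering 2,3-dihydro-1,4-benzodioxin-5-yl carries one more hydrogen-bond acceptor than the leaving 6-chloroquinolin-8-yl, and no measured pair separates two such groups. The expected step of a number 7 percentage points lower from compound 2 to compound 3 (within the scatter) is therefore none beyond the scatter, with a slight lean toward a lower number. Compound 3 is estimated at 28%, within 10% to 45%.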

Compound 3, a percentage reported as activity, at one dose (the size of the read-out at that dose, not a potency): 11%
Compound 3: the middle estimate sits 17 percentage points above what was measured; measured number inside the range.
By their numbers in this assay, from the lowest: compounds 3 and 1 (each within the scatter of the next); then compound 2.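

The group on the carbonyl carbon discriminates between two bicyclic groups: in this assay the exchange of 6-chloroquinolin-8-yl for 2,3-dihydro-1,4-benzodioxin-5-yl gives a number 24 percentage points lower from compound 2 to compound 3 (beyond the scatter) and thus removes the advantage compound 2 held in this series. Against the methyl group, the same 2,3-dihydro-1,4-benzodioxin-5-yl gives a number 7 percentage points lower from compound 1 to compound 3 (within the scatter) and so, among the three compounds, a bicyclic group on this carbonyl carbon does not by itself separate a compound from the methyl amide, with compound 3 going against any such pattern and only compound 2 standing apart. No measurement on hand accounts for the difference between the two bicyclic groups.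

The two groups differ at once in the chlorine, the ring nitrogen and the oxygen-bearing non-aromatic ring, so these compounds cannot assign the step to any one of these features. A plain quinolin-8-yl without the chlorine, or a naphthalen-1-yl with carbon in place of the ring nitrogen, would be the direct test of which feature goes with the higher number at this single dose.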